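The compounds below may be only part of what the source reports. "The series", "measured", "known", "first", "only" and "open" are said of these compounds alone.

compound 1 `COc1ccc(/C=C(/F)c2cc(OC)c(OC)c(OC)c2)cc1O`: 100 nM
compound 2 `COc1ccc(/C=C\c2cc(OC)c(OC)c(OC)c2)cc1[N+](=O)[O-]`: 113 nM

In a functional assay on HT-29 cells (Homo sapiens) for cytotoxicity, read by sulforhodamine B assay, with a stated time of 72 h (on this read-out lower numbers stand for stronger inhibition and higher numbers for weaker inhibition), compound 1 at 100 nM and compound 2 at 113 nM lie within the scatter of each other, so compound 1 does not stand apart. Compound 3 `COc1ccc(/C=C(/F)c2cc(OC)c(OC)c(OC)c2)cc1N` has not been measured. It differs from compound 1 (amino in place of hydroxy on an aromatic carbon) by amino in place of hydroxy on an aromatic carbon, ortho to a methoxy group. Among the compounds with values here, no measured pair shows this change. In this assay no step beyond the scatter is expected, with any move going slightly toward lower numbers. The expected size is a 1.4-fold lower number from compound 1 to compound 3 (0.15 log units; within the scatter) on this estimate. The estimate for compound 3 is 70 nM with an expected range from 15 nM to 320 nM for this read-out.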

Compound 3, half-maximal inhibitory concentration: 2.9 nM
Beside the measured number, compound 3's estimate is 24-fold (1.38 log units) above it; measured number outside the range, below it.
By their numbers in this assay, from the lowest: compound 3; then compounds 1 and 2 (each within the scatter of the next).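

In this assay, this position, ortho to a methoxy group, proves sensitive: amino in place of hydroxy gives a 34-fold lower number from compound 1 to compound 3 (1.54 log units; beyond the scatter) even though the counts of heavy atoms, hydrogen-bond donors and hydrogen-bond acceptors do not change. The earlier compounds shown here offered no matched pair here, so this sensitivity could not be read from them. Nothing measured on these compounds accounts for the step.

Whether the step extends beyond the free amino group stays open, as methylamino and acetamido groups at this place are not among the compounds shown. Also open, going by these compounds, is whether amino gives a similar step on the core without the fluorine.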